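The source may hold more compounds than are shown below. What is called first, only, known or untested is meant among the compounds shown, and "the series" means these compounds.

Measured in a functional assay, with a stated time of 10 min; on this read-out higher numbers stand for weaker inhibition and lower numbers for stronger inhibition:
Compound 1 `CCOc1cc(OC)c(Br)cc1C(C)=O`: 57700000 nM
Compound 2 `CCOc1cc(OC)ccc1C(C)=O`: 35300000 nM

Among the measured compounds shown here, compound 2, at 35300000 nM, cannot be separated from compound 1, as the one measured step shows: a 1.6-fold lower number from compound 1 to compound 2 (0.21 log units; within the scatter). Compound 3 `CCCCCCOc1cc(OC)ccc1C(C)=O` carries a longer chain: butyl in place of hydrogen on a saturated chain carbon, two bonds along the chain from an oxygen on an aromatic ring, with butyl in place of hydrogen on a saturated chain carbon, two bonds along the chain from an oxygen on an aromatic ring. The measured step concerns an aromatic carbon and not this chain, so it sets no size for this change. A modest move is expected, tentatively: a 2.4-fold lower number from compound 2 to compound 3 (0.37 log units; beyond the scatter). For compound 3 the estimated value is 15000000 nM, with an expected range of 3000000 nM to 60000000 nM.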

Compound 3, half-maximal inhibitory concentration: 84400000 nM
The estimate for compound 3 lay 5.6-fold (0.75 log units) below the measured number, outside the stated range (above it).
By their numbers in this assay, from the lowest: compounds 2, 1 and 3 (each within the scatter of the next, the first and the last beyond it).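

In this assay, among the compounds shown here, butyl in place of hydrogen on a saturated chain carbon, two bonds along the chain from an oxygen on an aromatic ring, gives the first step that lies beyond the scatter (a 2.4-fold higher number from compound 2 to compound 3 (0.38 log units; beyond the scatter)). This chain position therefore responds to the change, and the response is toward weaker inhibition, whereas the earlier step on the aromatic carbon stayed within the scatter. Nothing at hand bears on the reason for this step.

A single step sets no trend along the chain. As far as these compounds go, whether propyl would fall on the same side, or an amine or a carboxylic acid at the chain end would reverse the direction, remains open.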